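The source may hold more compounds than are shown below. What is called first, only, known or untested is meant among the compounds shown, and "the series" means these compounds.

Measured in a physicochemical assay for lipophilicity, using the shake flask method, in phosphate buffer, measured as octanol-water partition, with a stated time of 30 min, at pH 7.4; on this read-out lower numbers stand for lower lipophilicity and higher numbers for higher lipophilicity:
- compound 1 `C[C@@H]1CC(=O)N(c2cnc(NCc3c(F)ccc4c3CCO4)n3cnnc23)C1`: 1.8
- compound 2 `COCCC(=O)Nc1cnc(NCc2c(F)ccc3c2CCO3)n2cnnc12`: 1.4
- compound 3 `CN(c1ccn(C)n1)c1cnc(NCc2c(F)ccc3c2CCO3)n2cnnc12`: 1.8

Compound 3, at 1.8, stands level with compound 1 at the digits shown, and the two together hold the highest of the three numbers. Compound 4 `O=C1CC2(CC2)CN1c1cnc(NCc2c(F)ccc3c2CCO3)n2cnnc12` is the next to be read. Its structural change from compound 3 is a group of 8 heavy atoms (6 carbon, 1 nitrogen, 1 oxygen; one three-membered non-aromatic ring of carbon only, one five-membered non-aromatic ring with 1 hetero atom) in place of a group of 8 heavy atoms (5 carbon, 3 nitrogen; one five-membered aromatic ring with 2 hetero atoms), on an aromatic carbon. The exchange takes place on an aromatic carbon.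

Compound 1 carries 4-methyl-2-oxopyrrolidin-1-yl at this place, the measured group closest to the entering one. The most relevant measured step is therefore no change at the digits printed from compound 1 to compound 3 (within the scatter). The steps involving compound 2, a number 0.40 log units lower from compound 1 to compound 2 (beyond the scatter) and a number 0.40 log units higher from compound 2 to compound 3 (beyond the scatter), concern its open-chain amide and bear less directly. No step beyond the scatter is therefore expected in this assay. The expected step is a number 0.10 log units higher from compound 3 to compound 4 (within the scatter). The estimate for compound 4 is 1.9, with an expected range from 1.6 to 2.2.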

Compound 4, distribution coefficient: 1.9
Beside the measured number, compound 4's estimate shows no gap at the digits printed, and the stated range covers the measured number.
By their numbers in this assay, from the lowest: compound 2; then compounds 1, 3 and 4 (each within the scatter of the next).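

In this assay the entering group, with its three-membered non-aromatic ring of carbon only and its five-membered non-aromatic ring with 1 hetero atom, gives a number 0.10 log units higher from compound 1 to compound 4 (within the scatter) and a number 0.10 log units higher from compound 3 to compound 4 (within the scatter) when set against the two other ring-bearing groups at this aromatic carbon. Against the group with no ring the change reads a number 0.50 log units higher from compound 2 to compound 4 (beyond the scatter), so among the compounds shown only the open-chain amide stands apart from the others at this place. Nothing measured here explains these steps.

The compounds shown leave open whether a carboxylic acid or a primary amine on this aromatic carbon would stand apart from the ring-bearing groups. They also leave open whether a longer chain than ((2-methoxyethyl)carbonyl)amino would stay level with that open-chain amide.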